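The compounds below may be only part of what the source reports. "The series", "measured", "known", "first", "only" and "open" are said of these compounds alone.

Measured so far in a functional assay on HT-29 cells (Homo sapiens) for inhibition, read by luminescence and CellTiter-Glo, with a stated time of 24 h; on this read-out higher numbers stand for an effect only at larger amounts of compound and lower numbers for an effect already at smaller amounts:

compound 1, `CC(C)CCn1nc(C(=O)N[C@H]2COc3ccccc3N(C)C2=S)nc1Cc1ccccc1`: 3640 nM
compound 2, `CN1C(=S)[C@@H](NC(=O)c2nc(Cc3ccccc3)n(CCCCCC#N)n2)COc2ccccc21`: 3830 nM
compound 3, `CN1C(=S)[C@@H](NC(=O)c2nc(Cc3ccccc3)n(C3CCCCCC3)n2)COc2ccccc21`: 5530 nM

Compound 3 carries the highest of the three numbers in this assay, yet the two steps leading to it, a 1.5-fold higher number from compound 1 to compound 3 (0.18 log units; within the scatter) and a 1.4-fold higher number from compound 2 to compound 3 (0.16 log units; within the scatter), are both within the scatter, so the three compounds cannot be separated on these values. The third step, a 1.1-fold higher number from compound 1 to compound 2 (0.02 log units; within the scatter), is likewise within the scatter. Every exchange made so far at the aromatic nitrogen or along its chain has therefore left the number in this assay essentially unchanged.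

Compound 4, `Cc1cnc(-n2nc(C(=O)N[C@H]3COc4ccccc4N(C)C3=S)nc2Cc2ccccc2)nc1`, has not yet been measured. 5-methylpyrimidin-2-yl in place of cycloheptyl on an aromatic nitrogen

Among the measured compounds shown here, the steps that bear on this change are the two exchanges at the same aromatic nitrogen, which replaced one saturated group by another without effect beyond the scatter. For the measured compounds named here, no measured step brings an aromatic ring to that position, so the evidence for compound 4 is indirect. The working expectation is a step of a 1.1-fold lower number from compound 3 to compound 4 (0.04 log units; within the scatter), that is, nothing beyond the scatter, with a wide range to reflect the absence of a comparable measured step. Compound 4 is accordingly estimated at 5000 nM in this assay, with a range from 1800 nM to 14000 nM.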

Compound 4, half-maximal effective concentration: 1950 nM
Compound 4: the middle estimate sits 2.6-fold (0.41 log units) above what was measured; measured number inside the range.
By their numbers in this assay, from the lowest: compounds 4, 1, 2 and 3 (each within the scatter of the next, the first and the last beyond it).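

Notes on the substituent on the aromatic nitrogen: in this assay the 5-methylpyrimidin-2-yl group gives the first step in the series that lies beyond the scatter, with a 2.8-fold lower number from compound 3 to compound 4 (0.45 log units; beyond the scatter) as a modest change, and it is also the first aromatic ring at this position, where the saturated groups could not be separated from one another. The effect is limited, since a 2.0-fold lower number from compound 2 to compound 4 (0.29 log units; within the scatter) and a 1.9-fold lower number from compound 1 to compound 4 (0.27 log units; within the scatter) both remain within the scatter, so the position responds measurably only in the comparison with cycloheptyl, while compound 4 cannot be separated from the 5-cyanopentyl and isopentyl compounds. No accompanying measurement bears on what lies behind the step from cycloheptyl to 5-methylpyrimidin-2-yl.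

On these data alone, it remains open whether the aromatic ring itself, its two ring nitrogens or its methyl group accounts for the lower number, which a plain phenyl, a pyridin-2-yl or an unsubstituted pyrimidin-2-yl at the same nitrogen would help to separate. Also open, as far as these compounds go, is whether a second aromatic substituent such as a methoxy or a chloro on that ring would move the number further from the saturated compounds.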